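Alpha4/beta2 binding: 2-chlorophenyl ether replacing 4-fluorophenyl

A few compounds are considered here, and "the series" means these few. Any claim that something is new, unique, unknown or untested is made for them only; others in the source may bear on it.

Measured so far:
compound 1, `Fc1ccc(Oc2cncc(C3=CC4CNCC(C3)C4)c2)cc1`, 0.6 nM
compound 2, `CN1CC2C=C(c3ccc(F)nc3)CC(C2)C1`, 18 nM

Both values come from an in vitro assay on SH-EP1 cells for displacement of a labelled ligand from Neuronal acetylcholine receptor; alpha4/beta2 (Homo sapiens); on this read-out higher numbers stand for weaker inhibition and lower numbers for stronger inhibition. Compound 1 holds the lower of the two numbers, and the gap to compound 2 lies well beyond the usual scatter, so compound 1 is the stronger binder of the pair as it stands. Among the measured compounds shown here, no step between two measured compounds that differ in a single place is available, so nothing in the measured set directly calibrates a change at the aryl ether.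

Compound 3, `Clc1ccccc1Oc1cncc(C2=CC3CNCC(C2)C3)c1`, differs from compound 1 in one place:

2-chlorophenyl in place of 4-fluorophenyl on an oxygen on an aromatic ring

For the measured compounds named here, with no measured step to lean on, the direction and size of the change in this assay are uncertain. A modest weakening is expected, with the step of a 3.3-fold higher number from compound 1 to compound 3 (0.52 log units; beyond the scatter) likely to stay within a range that overlaps the scatter at its lower end. Compound 3 is therefore estimated at 2 nM, with a plausible span from 0.5 nM to 8 nM.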

Compound 3, inhibition constant: 0.9 nM
For compound 3 the middle estimate is 2.2-fold (0.35 log units) above the measured one; the measured number falls inside the stated range.
By their numbers in this assay, from the lowest: compounds 1 and 3 (each within the scatter of the next); then compound 2.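

In this assay, the aryl group on this oxygen now has its first calibrating step: 2-chlorophenyl in place of 4-fluorophenyl gives a 1.5-fold higher number from compound 1 to compound 3 (0.18 log units; within the scatter). Among the compounds shown here, the two compounds therefore cannot be told apart on this read-out, and the earlier compounds could not show that this position accepts either of these two halogen-bearing phenyl groups on the shared core without a separable difference in binding. No available evidence bears on why the two groups read alike.

For the compounds shown here, the single step changes both the halogen and its place on the phenyl ring, so it remains open whether 4-chlorophenyl or 2-fluorophenyl would read the same way and whether either feature matters on its own. Also open, going by these compounds, is how far this tolerance extends on the same oxygen, for instance to an unsubstituted phenyl, a pyridine ring, a methoxy-bearing phenyl or a saturated cyclohexyl group.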